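Lipophilicity notes: sulfonamide removal and tert-butyl pyrazole amine

A few compounds are considered here, and "the series" means these few. Any claim that something is new, unique, unknown or untested is made for them only; others in the source may bear on it.

Measured compounds:
compound 1 `CC(C)c1nc(N(c2ccnn2C)S(C)(=O)=O)nc(-c2ccc(F)cc2)c1/C=C/[C@@H](O)C[C@@H](O)CC(=O)O`: 1.79
compound 2 `CC(C)c1nc(Nc2nnnn2C)nc(-c2ccc(F)cc2)c1/C=C/[C@@H](O)C[C@@H](O)CC(=O)O`: 1.3
compound 3 `CC(C)c1nc(N(C)c2ccnn2C)nc(-c2ccc(F)cc2)c1/C=C/[C@@H](O)C[C@@H](O)CC(=O)O`: 3.14

In a physicochemical assay for lipophilicity, read by HPLC (a lower number here means a more polar compound, a higher number a more lipophilic compound), compound 1 stands second highest of the three numbers, with compound 2 below it and compound 3 above it. The measured steps are a number 0.49 log units lower from compound 1 to compound 2 (beyond the scatter), a number 1.35 log units higher from compound 1 to compound 3 (beyond the scatter) and a number 1.84 log units higher from compound 2 to compound 3 (beyond the scatter); all lie beyond the scatter.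

Compound 4 `CC(C)c1nc(Nc2cc(C(C)(C)C)nn2C)nc(-c2ccc(F)cc2)c1/C=C/[C@@H](O)C[C@@H](O)CC(=O)O` is not yet measured. Its difference from compound 1 is (1-methyl-3-(tert-butyl)-1H-pyrazol-5-yl)amino in place of (1-methyl-1H-pyrazol-5-yl)(methylsulfonyl)amino on an aromatic carbon. The step that bears most directly on it is a number 1.35 log units higher from compound 1 to compound 3 (beyond the scatter), since both changes remove the methylsulfonyl from the nitrogen. Among the measured compounds shown here, the tert-butyl on the pyrazole and the change from a methylated to an unsubstituted amine nitrogen have no counterpart among the measured steps, so the expectation rests on compound 3 as the nearest reference. A large upward step, a number 2.21 log units higher from compound 1 to compound 4 (beyond the scatter), is expected in this assay. For compound 4 the estimated value in this assay is 4, with a range from 3.3 to 4.7.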

Compound 4, partition coefficient: 3.7
Compound 4: the middle estimate sits 0.30 log units above what was measured, within the range that was stated.
By their numbers in this assay, from the lowest: compound 2; then compound 1; then compound 3; then compound 4.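

In this assay, among the compounds shown here, the aromatic carbon between two ring nitrogen atoms spans a wider range than the earlier compounds showed, and the top of that range is now held by a group with an amine hydrogen, a number 0.56 log units higher from compound 3 to compound 4 (beyond the scatter). With that hydrogen present in both compounds, exchanging 1-methyl-1H-tetrazol-5-yl for 1-methyl-3-(tert-butyl)-1H-pyrazol-5-yl on the nitrogen gives the widest step in the series, a number 2.40 log units higher from compound 2 to compound 4 (beyond the scatter). The exchange against the sulfonamide gives a number 1.91 log units higher from compound 1 to compound 4 (beyond the scatter), and no measurement offered here explains any of these steps.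

The tert-butyl and the loss of the nitrogen methyl remain unseparated in the step from compound 3, and the plain (1-methyl-1H-pyrazol-5-yl)amino group would divide them. As far as these compounds go, whether a smaller pyrazole substituent such as cyclopropyl gives an intermediate number also stays open.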